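Changing the sulfonyl group of compound 3

The compounds below may be only part of what the source reports. "The series", "measured", "known", "first", "only" and "open" are said of these compounds alone.

In an ADME assay on HEK-293T cells (Homo sapiens) for inhibition, read by CCK-8 assay, with a stated time of 48 h, tested at 20 uM (on this read-out higher numbers stand for more inhibition of growth at the one concentration tested and lower numbers for less inhibition of growth), compound 1 `Cc1ccc(S(=O)(=O)Oc2ccccc2/C=C(\C#N)C(=O)Nc2nnc(C)s2)cc1` stands at 35% on the read-out, compound 2 `CC(=O)Nc1ccc(S(=O)(=O)Oc2cccc(/C=C(\C#N)C(=O)Nc3nnc(-c4cccs4)s3)c2)cc1` stands at 20% and compound 3 `COc1ccc(Cc2nnc(NC(=O)/C(C#N)=C/c3ccccc3OS(=O)(=O)c3ccc(C)cc3)s2)cc1` stands at 21% in the same test. Compound 3 thus lies within the scatter of compound 2 and beyond the scatter under compound 1.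

Compound 4 `COc1ccc(Cc2nnc(NC(=O)/C(C#N)=C/c3ccccc3OS(=O)(=O)c3ccccc3[N+](=O)[O-])s2)cc1` departs from compound 3 in one place, with 2-nitrophenyl in place of 4-methylphenyl on a sulfonyl sulfur. The group that enters carries a ring of the same kind as the one that leaves, with no net charge on either.

Among the compounds with values here, only one single-place step has been measured so far (a number 14 percentage points lower from compound 1 to compound 3 (beyond the scatter)). It is a modest step, and it puts 4-methoxyphenyl in place of hydrogen on a saturated chain carbon bound to an aromatic carbon, which is not the place that changes here. Within the data shown here, no measured step replaces the group on the sulfonyl sulfur, so the data give no direct guide to size or direction.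

A step beyond the scatter is therefore not expected, and the estimated change is a number 1 percentage points higher from compound 3 to compound 4 (within the scatter) at this stage. In this assay the estimated value for compound 4 is 22% with an expected range from 8% to 38% for now.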

Compound 4, percent growth inhibition at one concentration: 18%
Beside the measured number, compound 4's estimate is 4 percentage points above it; the measured number falls inside the stated range.
By their numbers in this assay, from the lowest: compounds 4, 2 and 3 (each within the scatter of the next); then compound 1.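

The sulfonyl sulfur, whose other neighbour is oxygen on an aromatic ring, now has its first measured replacement: this assay gives a number 3 percentage points lower from compound 3 to compound 4 (within the scatter) when 2-nitrophenyl stands in place of 4-methylphenyl. Within this pair, then, a group with 2 hydrogen-bond acceptors and a nitrogen and two oxygens in its atom count can take the place of a group with 0 hydrogen-bond acceptors and no heteroatoms, and the read-out cannot be told apart from that of compound 3. Nothing measured alongside these compounds says why this exchange stays inside the scatter.

Within the data shown here, the one pair also speaks only for groups that carry a six-membered aromatic ring of carbon only, so what a methyl group, or a phenyl ring bearing an amine or a carboxylic acid, would give on the sulfonyl sulfur remains open. On these data alone, it is equally open whether the same exchange would read the same way on the core of compound 1, which stands at 35% with 4-methylphenyl in this place.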